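Amide-linked aryl series: sulfonamide variation at the aromatic carbon

The compounds below may be only part of what the source reports. "The series", "measured", "known", "first", "only" and "open" are said of these compounds alone.

Two compounds of the series carry numbers in an assay on cells for antagonist activity at transient receptor potential cation channel subfamily V member 1 (Homo sapiens), read by FLIPR and calcium flux, with a stated time of 15 min; a higher number here means a weaker inhibitor, a lower number a stronger inhibitor. Compound 1 `CC1CCN(c2nc(C(F)(F)F)ccc2CNC(=O)C(C)c2cc(F)c(NS(C)(=O)=O)c(Br)c2)CC1` gives 0.7 nM in this assay, and compound 2 `CC1CCN(c2nc(C(F)(F)F)ccc2CNC(=O)C(C)c2ccc(NS(=O)(=O)C(C)C)c(F)c2)CC1` gives 8.7 nM. Within these two values compound 2 stands highest; the gap to compound 1 lies beyond the scatter, so compound 2 is the weaker inhibitor of the pair. For the measured compounds named here, no step between measured compounds that differ in only one place exists in this set, so the size of any single change has to be judged without a direct precedent.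

Compound 3 `CC(=O)N(c1ccc(C(C)C(=O)NCc2ccc(C(F)(F)F)nc2N2CCC(C)CC2)cc1F)S(C)(=O)=O` has not yet been measured in this assay. It is derived from compound 2 by one change: acetyl(methylsulfonyl)amino in place of (isopropylsulfonyl)amino on an aromatic carbon. Going by the values given here, with no comparable step on record, the expectation for compound 3 rests on the position of compound 2 alone, and the step is expected to move the number upward, toward a weaker inhibitor, by a 6.9-fold higher number from compound 2 to compound 3 (0.84 log units; beyond the scatter), likely beyond the scatter. Compound 3 is therefore estimated at 60 nM in this assay, with a range from 10 nM to 400 nM.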

Compound 3, inhibition constant: 11.9 nM
For compound 3 the middle estimate is 5.0-fold (0.70 log units) above the measured one; low and high end bracket the measured number.
By their numbers in this assay, from the lowest: compound 1; then compounds 2 and 3 (each within the scatter of the next).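

In this assay, for the compounds shown here, the replacement of (isopropylsulfonyl)amino by acetyl(methylsulfonyl)amino on an aromatic carbon, ortho to a fluoro group and para to a large group, gives a 1.4-fold higher number from compound 2 to compound 3 (0.14 log units; within the scatter) and is the first single-place step on record for the series. The hydrogen-bond donor counted in (isopropylsulfonyl)amino is absent from acetyl(methylsulfonyl)amino, yet the two compounds stay within the scatter of each other, so in this pair a number in this range does not depend on that donor. Nothing on record accounts for this outcome.

The single step alters two things at once, the acetyl group on the nitrogen and the sulfonyl substituent, and the compounds shown do not separate their contributions, since neither the plain (methylsulfonyl)amino group nor an N-acetyl version of the (isopropylsulfonyl)amino group appears on this core with the same fluoro arrangement. Going by these compounds, it also remains open how far this position accepts other groups, such as a longer chain like n-butylsulfonylamino, a benzoyl group in place of acetyl, or a free amine.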